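A few compounds are considered here, and "the series" means these few. Any claim that something is new, unique, unknown or untested is made for them only; others in the source may bear on it.

Working notes on the series. Compound 1 `CCCCC[C@H](CCC[C@@H]1CC=CC(=O)O1)OC` gives 20500 nM in a functional assay on A2780 ADR cells (Homo sapiens) for cytotoxicity, read by MTT assay, with a stated time of 24 h; a higher number here means a weaker inhibitor, a lower number a stronger inhibitor. Compound 2 `CCCCC[C@H](C[C@@H](O)C[C@@H]1CC=CC(=O)O1)OC` carries hydroxy in place of hydrogen on a saturated chain carbon bound to two saturated chain carbons and gives 91500 nM in this assay, a step of a 4.5-fold higher number from compound 1 to compound 2 (0.65 log units; beyond the scatter). Compound 3 `CCCCC[C@H](CCC[C@H]1CC=CC(=O)O1)OC` has the same atoms and bonds as compound 1 (the two compounds have the same atoms and bonds and differ only in configuration as drawn: 1 of 2 stereo elements differ; a stereocentre at a saturated ring carbon is drawn R in compound 1 and S in compound 3). In this assay compound 3 gives 12200 nM; the step of a 1.7-fold lower number from compound 1 to compound 3 (0.23 log units; within the scatter) stays within the scatter, consistent with the fact that compounds 1 and 3 differ only in the configuration as drawn. Compound 4 `CCCCC[C@H](C[C@H](O)C[C@H]1CC=CC(=O)O1)OC` is not yet measured; relative to compound 3 it carries hydroxy in place of hydrogen on a saturated chain carbon bound to two saturated chain carbons, the same change as in the measured pair, with the place worded identically in both. Resting on a 4.5-fold higher number from compound 1 to compound 2 (0.65 log units; beyond the scatter), the step of a 4.5-fold higher number from compound 3 to compound 4 (0.65 log units; beyond the scatter) is expected in this assay. Compound 4 is accordingly estimated at 55000 nM in this assay, with a likely range of 20000 nM to 150000 nM.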

Compound 4, half-maximal inhibitory concentration: 57500 nM
Compound 4: middle estimate off by 1.0-fold (0.02 log units), on the low side; the measured number falls inside the stated range.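

In this assay, hydroxy in place of hydrogen on a saturated chain carbon bound to two saturated chain carbons carries over from one core to the other, with a 4.7-fold higher number from compound 3 to compound 4 (0.67 log units; beyond the scatter) matching the earlier step: the same change on two cores in this assay, a 4.5-fold higher number (0.65 log units; beyond the scatter) from compound 1 to compound 2 and a 4.7-fold higher number (0.67 log units; beyond the scatter) from compound 3 to compound 4, 1.1-fold (0.02 log units) apart, within the scatter of two such steps.
The hydroxy compounds also stay within the scatter of each other, with a 1.6-fold lower number from compound 2 to compound 4 (0.20 log units; within the scatter): the fact that compounds 2 and 4 differ only in the configuration as drawn.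
This shows transfer only between two cores of opposite ring configuration as drawn, and it does not show that the step would hold on a core with different atoms and bonds.

Open, from the compounds shown here alone, is whether an amine or a carboxylic acid at the same place would give a step of similar size. Also open, going by these compounds, is whether the step would persist with a longer chain.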